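The compounds below may be only part of what the source reports. "The series", "measured", "known", "first", "only" and "open" are said of these compounds alone.

In a functional assay on FaDu cells (Homo sapiens) for cytotoxicity, read by MTT assay, with a stated time of 72 h (a lower number here means that less compound is tolerated, a higher number that more compound is tolerated), compound 1 `CCn1cc(C(=O)C(=O)Nc2ccc(OC)nc2)c2ccccc21` gives 219 nM. Compound 2 `COc1ccc(NC(=O)C(=O)c2cn(CC(C)(C)OC)c3ccccc23)cn1` gives > 10000 nM, which is a limit of the assay and not a number. Going by these compounds, compound 3 `COc1ccc(NC(=O)C(=O)c2cn(CCC(=O)O)c3ccccc23)cn1` gives > 10000 nM, again only a limit, so its true value is unknown. Compound 4 `COc1ccc(NC(=O)C(=O)c2cn(CC(C)C)c3ccccc23)cn1` differs from it by isopropyl in place of carboxymethyl on a saturated chain carbon bound to an aromatic nitrogen. For the measured compounds named here, two measured steps bear on this change, both large and beyond the scatter. Adding carboxy gave an at least 45-fold higher number from compound 1 to compound 3 (1.65 log units; beyond the scatter), so losing it should move the number back down. However, the larger chain gave an at least 45-fold higher number from compound 1 to compound 2 (1.65 log units; beyond the scatter), so the return may be only partial. The expected change is an at least 14-fold lower number from compound 3 to compound 4 (1.15 log units; beyond the scatter), towards a lower number. Compound 4 is estimated at 700 nM, with an expected range of 80 nM to 6000 nM.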

Compound 4, concentration lethal to 50% of the cells: 317 nM
Compound 4: the middle estimate sits 2.2-fold (0.34 log units) above what was measured; measured number inside the range.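

Isopropyl in place of carboxymethyl gives an at least 31-fold lower number from compound 3 to compound 4 (1.49 log units; beyond the scatter). Isopropyl in place of methyl gives a 1.4-fold higher number from compound 1 to compound 4 (0.16 log units; within the scatter), so a branched chain at this place does not by itself bring the high number. Hydrogen in place of methoxy gives an at least 31-fold lower number from compound 2 to compound 4 (1.49 log units; beyond the scatter), so in this pair one methoxy group separates a low number from a high one.

Compound 2 and compound 3 both stand at limits of the assay, not numbers, and the step between them cannot be read: the limit of > 10000 nM in this assay, at which 2 of the 4 values shown sit.

Going by these compounds, whether an amine or a hydroxyl on this chain would also push the number up remains open.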